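The compounds below may be only part of what the source reports. "The series", "measured", "known", "first", "only" and "open" are said of these compounds alone.

Measured so far:
compound 1 `CNCCOc1cccc2ccccc12` gives 26 nM in a functional assay for agonist activity at 5-hydroxytryptamine receptor 1B (Homo sapiens); on this read-out higher numbers stand for weaker inhibition and lower numbers for stronger inhibition
compound 2 `CCNCCOc1cccc2ccccc12` gives 66 nM

Of these two numbers, compound 2 holds the higher one, with compound 1 nearest at a 2.5-fold higher number from compound 1 to compound 2 (0.40 log units; beyond the scatter). The step to compound 3 `CCCNCCOc1cccc2ccccc12` is methyl in place of hydrogen on a saturated chain carbon, two bonds along the chain from an amine nitrogen. Among the measured compounds shown here, the only measured step that bears on it, a 2.5-fold higher number from compound 1 to compound 2 (0.40 log units; beyond the scatter), added a carbon at the same chain in the same direction and gave a modest rise. Extending the chain once more is therefore expected to move the number the same way, by a step of similar size, a 2.0-fold higher number from compound 2 to compound 3 (0.29 log units; within the scatter). Compound 3 is thus expected to give about 130 nM, within 50 nM to 350 nM.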

Compound 3, inhibition constant: 200 nM
For compound 3 the middle estimate is 1.5-fold (0.19 log units) below the measured one; the measured number falls inside the stated range.
By their numbers in this assay, from the lowest: compound 1; then compound 2; then compound 3.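

Changing ethylamino to propylamino weakens inhibition again in this assay, with a 3.0-fold higher number from compound 2 to compound 3 (0.48 log units; beyond the scatter), so the rise seen on the first chain extension was not a single event. Taken end to end, the series gives a 7.7-fold higher number from compound 1 to compound 3 (0.89 log units; beyond the scatter), and each lengthening of the chain on the shared core moves the number the same way, with no listed compound going against this. Nothing available explains why longer chains at this position give higher numbers.

On these data alone, whether a butyl chain would continue the rise remains open. So does whether a branched isopropyl group or a cyclopropyl ring in place of propyl would follow the same trend.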